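Lengthening the amide chain on two related cores

The compounds below may be only part of what the source reports. "The series", "measured", "known", "first", "only" and "open" are said of these compounds alone.

Compound 1 `O=C(Nc1ncc(Cc2cccc3ccccc23)s1)C1CCCCC1` and compound 2 `O=C(CCC1CCCCC1)Nc1ncc(Cc2cccc3ccccc23)s1` share one core and differ only in the group on the carbonyl: 2-cyclohexylethyl in place of cyclohexyl on a carbonyl carbon. In an ADME assay on P388D1 cells (Mus musculus) for cytotoxicity, read by fluorescence and resazurin assay, with a stated time of 72 h (a lower number here means a stronger inhibitor, a higher number a weaker inhibitor), compound 1 reaches only a limit, > 40000 nM. In this assay compound 2 gives 27600 nM. The resulting step, an at least 1.4-fold lower number from compound 1 to compound 2 (0.16 log units; that floor lies within the scatter), is set by the limit of > 40000 nM in this assay, at which 2 of the 3 values shown sit. Compound 3 `O=C(Nc1ncc(Cc2cccc3c2CCC3)s1)C1CCCCC1` carries the cyclohexyl amide on a second core; the difference between the two cores is not broken down here. In this assay compound 3 also reaches only a limit, > 40000 nM. Compound 4 `O=C(CCC1CCCCC1)Nc1ncc(Cc2cccc3c2CCC3)s1` is the unmeasured partner of compound 3 with the same change: 2-cyclohexylethyl in place of cyclohexyl on a carbonyl carbon. The expected step is an at least 1.3-fold lower number from compound 3 to compound 4 (0.12 log units; that floor lies within the scatter), which rests on the measured step of an at least 1.4-fold lower number from compound 1 to compound 2 (0.16 log units; that floor lies within the scatter). Compound 4 is therefore expected to give about 30000 nM, in a range from 12000 nM to 60000 nM, with a fair chance that only a limit is reported.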

Compound 4, half-maximal inhibitory concentration: > 40000 nM
Compound 4 was reported as a limit; the forecaster's own chance of this, stated with the estimate: 45%; middle value at least 1.3-fold (0.12 log units) away from the limit.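

Compound 3 and compound 4 both reach only a limit in this assay, so the step between them cannot be read: the limit of > 40000 nM in this assay, at which 3 of the 4 values shown sit.

Going by these compounds, whether the longer 2-cyclohexylethyl chain changes the number on the core of compound 3 stays open.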